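Flipping two ring stereocentres on the way from compound 3 to compound 4

The source may hold more compounds than are shown below. What is called first, only, known or untested is meant among the compounds shown, and "the series" means these compounds.

Measured so far:
- compound 1, `COC(=O)N[C@H](C(=O)N1CCC[C@H]1C(=O)Nc1ccc([C@H]2CC[C@H](c3ccc(NC(=O)[C@@H]4CCCN4C(=O)[C@@H](NC(=O)OC)C(C)C)cc3)N2c2ccc(C(F)(F)F)cc2)cc1)C(C)C`: 58%
- compound 2, `COC(=O)N[C@H](C(=O)N1CCC[C@H]1C(=O)Nc1ccc([C@@H]2CC[C@@H](c3ccc(NC(=O)[C@@H]4CCCN4C(=O)[C@@H](NC(=O)OC)C(C)(C)C)cc3)N2c2ccc(F)cc2)cc1)C(C)(C)C`: 52%
- compound 3, `COC(=O)N[C@H](C(=O)N1CCC[C@H]1C(=O)Nc1ccc([C@@H]2CC[C@@H](c3ccc(NC(=O)[C@@H]4CCCN4C(=O)[C@@H](NC(=O)OC)C(C)C)cc3)N2c2ccc(F)cc2)cc1)C(C)C`: 44%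

All three compounds share one large core and were tested in an ADME assay (liver) for metabolic stability, with Liver microsome (Homo sapiens) as the target, using microsomes, with a stated time of 30 min; a lower number here means that less of the compound is left, a higher number that more of the compound is left. Compound 3 stands at the bottom of the three numbers with 44%. Its nearest neighbour is compound 2, whose value lies within the scatter of that of compound 3, so the two cannot be told apart. Compound 1 lies furthest away, and its gap to compound 3 is beyond the scatter.

The unmeasured compound 4, `COC(=O)N[C@H](C(=O)N1CCC[C@H]1C(=O)Nc1ccc([C@H]2CC[C@H](c3ccc(NC(=O)[C@@H]4CCCN4C(=O)[C@@H](NC(=O)OC)C(C)C)cc3)N2c2ccc(F)cc2)cc1)C(C)C`, is built from exactly the same atoms and bonds as compound 3. For the measured compounds named here, the only change is this: the two compounds have the same atoms and bonds and differ only in configuration as drawn: 2 of 6 stereo elements differ; a stereocentre at a saturated ring carbon is drawn S in compound 3 and R in compound 4; a stereocentre at a saturated ring carbon is drawn S in compound 3 and R in compound 4. In words, the two stereocentres at saturated ring carbons that are drawn S in compound 3 are drawn R in compound 4, while the other four stereo elements stay as they are. Going by the values given here, no pair of measured compounds differs in this way alone, so the size of such a step is unknown here. At those two ring carbons compound 4 carries the same drawn configuration as compound 1, and compound 1 gives 58%. Compound 1 also differs from compound 4 in another place, however, so this is only a hint.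

Compound 4 is therefore expected to sit a little above compound 3, by the step of a number 6 percentage points higher from compound 3 to compound 4 (within the scatter), a change that may well stay within the scatter. The estimate for compound 4 in this assay is 50%, with a range from 36% to 64%.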

Compound 4, percent of the compound remaining: 38%
Estimate against measurement, compound 4: 12 percentage points above; the measured number falls inside the stated range.
By their numbers in this assay, from the lowest: compounds 4, 3, 2 and 1 (each within the scatter of the next, the first and the last beyond it).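

In this assay, reversing the two ring stereocentres gives a number 6 percentage points lower from compound 3 to compound 4 (within the scatter), so at these two saturated ring carbons the drawn configuration produces no difference that can be told apart from the scatter, and this reading is not mixed with any other structural change: the fact that compounds 3 and 4 differ only in the configuration as drawn. Compound 1 and compound 4 carry the same drawn configuration at those carbons and differ in one place, fluoro in place of trifluoromethyl on an aromatic carbon, and that change gives a number 20 percentage points lower from compound 1 to compound 4 (beyond the scatter). Within this pair, then, a gap beyond the scatter appears with the exchange of the aromatic substituent, whereas the stereocentre pair shows none.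

On these data alone, it remains open whether the two ring configurations would also stay within the scatter of each other with trifluoromethyl on the aromatic carbon, since the fluoro pair is the only one that can be read this way. Also open, as far as these compounds go, is how a nitrile, a chlorine or a methoxy group on that aromatic carbon would compare with fluoro and trifluoromethyl.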